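A Methyl Added to the Ether Chain of Compound 2

The source may report more compounds than this note shows. Statements on the series, on what has been measured and on what is new or still open speak of the compounds shown alone.

Three compounds sharing one core were measured in a functional assay on DU-145 cells (Homo sapiens) for cytotoxicity, read by MTT assay; on this read-out lower numbers stand for stronger inhibition and higher numbers for weaker inhibition:

compound 1 `CCCCC(O)CC(=O)O[C@H](CC=C(C)C)C1=CC(=O)c2c(O)ccc(O)c2C1=O` gives 45300 nM
compound 2 `COC(C)CO[C@H](CC=C(C)C)C1=CC(=O)c2c(O)ccc(O)c2C1=O` gives 16600 nM
compound 3 `CC(C)=CC[C@@H](OC(=O)CC(C)(O)C(C)C)C1=CC(=O)c2c(O)ccc(O)c2C1=O` gives 16900 nM

Compound 2 has the lowest of the three numbers, but its gap to compound 3 is within the scatter, so the two cannot be told apart; only compound 1 stands clearly apart, with a 2.7-fold lower number from compound 1 to compound 2 (0.44 log units; beyond the scatter).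

The unmeasured compound 4 `CCC(CO[C@H](CC=C(C)C)C1=CC(=O)c2c(O)ccc(O)c2C1=O)OC` differs from compound 2 by methyl in place of hydrogen on a saturated chain carbon, two bonds along the chain from an oxygen on a saturated carbon. The change is small: a single carbon joins the chain of the ether group, and nothing else moves.

Among the compounds with values here, no measured step tests this particular change. The steps that exist swap whole groups on the same oxygen, as in a 2.7-fold lower number from compound 1 to compound 2 (0.44 log units; beyond the scatter) and a 1.0-fold higher number from compound 2 to compound 3 (0.01 log units; within the scatter), and they show that even exchanging an ester for an ether, or one ester for another of a different shape, moves the number by modest amounts or not at all. A lone methyl added two bonds from that oxygen is a far smaller change than any of these.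

Compound 4 is therefore expected to sit close to compound 2, with an expected step of a 1.0-fold lower number from compound 2 to compound 4 (0.02 log units; within the scatter) that should stay within the scatter. Compound 4 is estimated at 16000 nM, with a range from 7500 nM to 34000 nM.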

Compound 4, half-maximal inhibitory concentration: 45700 nM
Estimate against measurement, compound 4: 2.9-fold (0.46 log units) below; measured number outside the range, above it.
By their numbers in this assay, from the lowest: compounds 2 and 3 (each within the scatter of the next); then compounds 1 and 4 (each within the scatter of the next).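

In this assay, one added methyl on a saturated chain carbon, two bonds along the chain from an oxygen on a saturated carbon, gives a 2.8-fold higher number from compound 2 to compound 4 (0.44 log units; beyond the scatter) and so counts as a real change, of the same printed size as the exchange of a whole group in a 2.7-fold lower number from compound 1 to compound 2 (0.44 log units; beyond the scatter) even though it involves far fewer atoms. The new compound also separates from the ester compound 3 with a 2.7-fold higher number from compound 3 to compound 4 (0.43 log units; beyond the scatter) in the same direction, whereas a 1.0-fold higher number from compound 1 to compound 4 (0.00 log units; within the scatter) means that the 2-methoxybutyl ether cannot be told apart from the ester of compound 1 on this read-out. Nothing at hand gives a reason for this effect of the methyl.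

Still open, as far as these compounds go, is whether a propyl group in place of the ethyl on that carbon would push the number further in the same direction, or whether an amine there would bring it back towards compound 2. The compounds shown also leave open how a methyl on any other carbon of this ether chain would behave.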